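Amide-side swap on a shared core: compound 2 to compound 4

A few compounds are considered here, and "the series" means these few. Any claim that something is new, unique, unknown or untested is made for them only; others in the source may bear on it.

Three compounds have numbers in an assay for binding affinity to CDK8/Cyclin C (Homo sapiens), read by FRET and LanthaScreen, with stated times of 20 min and 2 h, tested at 10 uM; on this read-out lower numbers stand for less inhibition and higher numbers for more inhibition at the one concentration tested (going by the name of the read-out). Compound 1 `CCc1ccccc1NC(=O)Cn1c(C)cc(=O)n2nc(-c3ccc(Cl)cc3)nc12` gives 35.3%. Compound 2 `CCOCCCNC(=O)c1ccc(-n2c(-c3ccccc3)nc3cccnc32)cc1` gives 26.1%, which sits with compound 1 inside the usual scatter and stands well clear of compound 3 `COc1ccc(NC(=O)c2sc(COc3ccc(Cl)c(C)c3)nc2C)cc1`, whose reading of -7.6% lies beyond the scatter on the lower side. Compound 4 `O=C(NCc1cccnc1)c1ccc(-n2c(-c3ccccc3)nc3cccnc32)cc1` has not been measured; it differs from compound 2 by pyridin-3-yl in place of 2-ethoxyethyl on a saturated chain carbon bound to an amide-type nitrogen. For the measured compounds named here, no pair of measured compounds separated by a single change is available, so the size of this step is not anchored by any measured step. The step is expected to be small, likely none beyond the scatter, and is estimated as a number 1.9 percentage points higher from compound 2 to compound 4 (within the scatter). In this assay compound 4 is expected to give 28%, with a range from 5% to 50%.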

Compound 4, a percentage reported as inhibition, at one concentration (the size of the read-out at that concentration, not a potency): 38.9%
Compound 4: middle estimate off by 10.9 percentage points, on the low side; measured number inside the range.
By their numbers in this assay, from the lowest: compound 3; then compounds 2, 1 and 4 (each within the scatter of the next, the first and the last beyond it).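

For the compounds shown here, this is the first single-place comparison. On the shared core, in this assay, pyridin-3-yl in place of 2-ethoxyethyl on a saturated chain carbon bound to an amide-type nitrogen gives a number 12.8 percentage points higher from compound 2 to compound 4 (beyond the scatter), so the reading responds to this position, and a ring is accepted where the open chain stood. Nothing at hand accounts for the step.

Going by these compounds, whether the ring as such or its nitrogen carries the step stays open; a cyclohexyl or piperidinyl group in the same place would bear on that. Potency also stays open, as only one concentration is reported.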